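Will a 4-carboxy-2-chlorophenyl group lift compound 1?

This account rests on a few compounds, and the source may have more. Where it says the series, first, only, none or still open, it means among the compounds named here.

Measured in an ADME assay on microsomes from liver (Rattus norvegicus) for metabolic stability, read by LC-MS, with a stated time of 1 h, at 37 degrees C, tested at 4 uM (on this read-out lower numbers stand for a less stable compound and higher numbers for a more stable compound), so far:
- Compound 1 `O=C1c2ccc(OCc3cccc(-c4ccccc4)c3)cc2CN1C1CCCC1` gives 38%
- Compound 2 `O=C(O)c1cc(-c2cccc(COc3ccc4c(=O)n(C5CCCC5)sc4c3)c2)cc([N+](=O)[O-])c1` gives 84%
- Compound 3 `O=C(O)c1cc(-c2cccc(COc3ccc4c(=O)n(C5CC5)sc4c3)c2)ccc1Cl` gives 86%

Compound 1 is the lowest of the three, and both compound 2 and compound 3 lie above it by more than the usual scatter. The next compound to be tested, compound 4 `O=C(O)c1ccc(-c2cccc(COc3ccc4c(c3)CN(C3CCCC3)C4=O)c2)c(Cl)c1`, keeps the core of compound 1 and changes one group: 4-carboxy-2-chlorophenyl in place of phenyl on an aromatic carbon.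

Among the compounds with values here, no measured pair here differs in only one place, so the size of this change cannot be read directly. The only hint is indirect. Compound 2 (at 84%) and compound 3 (at 86%) each carry a carboxy group that compound 1 lacks, although their core is different. A clear rise is therefore expected in this assay (an estimated a number 36 percentage points higher from compound 1 to compound 4 (beyond the scatter)) but probably a little short of those two values, and this is uncertain. The estimated value for compound 4 is 74% (expected range 52% to 92%).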

Compound 4, percent of the compound remaining: 3%
Estimate against measurement, compound 4: 71 percentage points above; the measured number lies below the stated range.
By their numbers in this assay, from the lowest: compound 4; then compound 1; then compounds 2 and 3 (each within the scatter of the next).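

Within the data shown here, the change from phenyl to 4-carboxy-2-chlorophenyl gives a number 35 percentage points lower from compound 1 to compound 4 (beyond the scatter) in this assay and so offers the first direct reading of this position. On the core of compound 1, the group on this aromatic carbon clearly matters, and the high numbers of compound 2 and compound 3, which also carry a carboxy group on a different core, do not carry over to this core. Nothing measured here accounts for the fall in stability.

From the compounds shown here alone, since the carboxylic acid and the chlorine enter together, it remains open whether a phenyl ring carrying only one of them would give a similar fall. Also open, going by these compounds, is how an amine or a methyl ester in place of the carboxylic acid would behave on this core.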